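The source may hold more compounds than are shown below. What is called first, only, known or untested is meant among the compounds shown, and "the series" means these compounds.

In an ADME assay on microsomes from liver (Canis lupus familiaris) for metabolic stability, read by LC-MS, tested at 1 uM (a higher number here means faster removal of the compound, a lower number slower removal), compound 1 (`NCCCOc1ccc([C@H]2CC[C@]3(CC2)OOC2(O3)C3CC4CC(C3)CC2C4)cc1`) gives < 7 mL.min-1.g-1, a limit and not a number. Compound 2 (`N[C@H]1CC[C@@H](Oc2ccc([C@H]3CC[C@]4(CC3)OOC3(O4)C4CC5CC(C4)CC3C5)cc2)CC1`) gives < 7 mL.min-1.g-1, also a limit, so its position is known only as the limit of < 7 mL.min-1.g-1 in this assay, at which 2 of the 2 values shown sit. Going by the values given here, the sole measured step is a step that the two limits leave unreadable from compound 1 to compound 2, and it offers no size to carry forward. Compound 3 (`CC1(C)CC(O)(COc2ccc([C@H]3CC[C@]4(CC3)OOC3(O4)C4CC5CC(C4)CC3C5)cc2)CC(C)(C)N1`) differs from compound 2 as follows: (4-hydroxy-2,2,6,6-tetramethylpiperidin-4-yl)methyl in place of 4-aminocyclohexyl on an oxygen on an aromatic ring. With no readable step to go on, the change expected in this assay is a step that the limit leaves unreadable from compound 2 to compound 3, with no direction favoured and nothing expected beyond the scatter. Compound 3 is expected at 6 mL.min-1.g-1, within an estimated range of 3 mL.min-1.g-1 to 13 mL.min-1.g-1.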

Compound 3, intrinsic clearance in microsomes: < 7 mL.min-1.g-1
Compound 3 gave a limit, no number; the forecaster's own chance of this, stated with the estimate: 60%; the middle value lies beyond the limit too.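

Compound 3 also gives only a limit in this assay, so neither step to it, from compound 1 or from compound 2, can be read. The compounds shown leave open whether these three differ at all in intrinsic clearance in microsomes.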